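Extending the amide nitrogen of compound 1

The compounds below may be only part of what the source reports. "The series", "measured", "known", "first", "only" and "open" are said of these compounds alone.

Compound 1 `COc1cc(-c2nc3cc(/C=C4\SC(=O)NC4=O)ccc3[nH]2)cc(OC)c1OC` is one of three analogues that share a common core and differ in the substituents on the aryl ring. In a functional assay on HeLa cells (Homo sapiens) for inhibition, read by MTT assay, with a stated time of 48 h (on this read-out higher numbers stand for weaker inhibition and lower numbers for stronger inhibition), compound 1 gives 1670 nM, the lowest of the three numbers. Compound 2 `COc1ccc(-c2nc3cc(/C=C4\SC(=O)NC4=O)ccc3[nH]2)cc1OC` gives 7830 nM; the step of a 4.7-fold higher number from compound 1 to compound 2 (0.67 log units; beyond the scatter). Compound 3 `COc1cc(-c2nc3cc(/C=C4\SC(=O)NC4=O)ccc3[nH]2)ccc1OCC(C)C` gives 5220 nM; the step of a 1.5-fold lower number from compound 2 to compound 3 (0.18 log units; within the scatter). Compound 1 thus stands apart from both companions, beyond the scatter in each case.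

Compound 4 `COc1cc(-c2nc3cc(/C=C4\SC(=O)N(CC(=O)N5CCCCC5)C4=O)ccc3[nH]2)cc(OC)c1OC` is not yet measured. It differs from compound 1 by ((piperidin-1-yl)carbonyl)methyl in place of hydrogen on an amide-type nitrogen in a ring. Neither measured step touches this position: the changes from compound 1 to compound 2 and from compound 2 to compound 3 concern only the aryl substituents, so nothing here tells how the ring nitrogen of the shared core tolerates substitution. Within the data shown here, the one step on the aryl ring that went beyond the scatter was modest, and the other stayed within it. Among the measured compounds shown here, with no precedent for the nitrogen, compound 4 is expected to stay near compound 1, a step of a 1.3-fold higher number from compound 1 to compound 4 (0.12 log units; within the scatter), with a wide range either way. Compound 4 is therefore estimated at 2200 nM, between 600 nM and 8000 nM.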

Compound 4, half-maximal inhibitory concentration: 23300 nM
Beside the measured number, compound 4's estimate is 11-fold (1.02 log units) below it; measured number outside the range, above it.
By their numbers in this assay, from the lowest: compound 1; then compounds 3 and 2 (each within the scatter of the next); then compound 4.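

Replacing the amide hydrogen with ((piperidin-1-yl)carbonyl)methyl on the ring nitrogen, two ring bonds from the ring sulfur, gives in this assay a 14-fold higher number from compound 1 to compound 4 (1.14 log units; beyond the scatter). Among these compounds, the position is therefore not neutral on this read-out: this single change on the nitrogen produces a large step, whereas the only aryl step beyond the scatter, a 4.7-fold higher number from compound 1 to compound 2 (0.67 log units; beyond the scatter), was modest. Nothing available explains the loss, so the result records its size and place but not its cause.

With only one substituent on this nitrogen, the compounds shown cannot separate the loss of the amide hydrogen from the contribution of the added chain, and so leave open whether the piperidine ring, the carbonyl or the mere presence of a substituent accounts for the higher number. A plain methyl on the same nitrogen, or a carboxylic acid or a morpholine amide at the end of the same chain, would address that question, and the same ((piperidin-1-yl)carbonyl)methyl group on compound 2 or compound 3 would show whether the step holds with other aryl substituents.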